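A few compounds are considered here, and "the series" means these few. Any claim that something is new, unique, unknown or untested is made for them only; others in the source may bear on it.

In a functional assay on SW-620 cells (Homo sapiens) for antiproliferative activity, read by MTT assay, with a stated time of 24 h (a lower number here means a stronger inhibitor, a higher number a weaker inhibitor), three compounds have been measured so far. Compound 1 `COc1ccc(C(=O)/C=C/c2cc(OC)c(OC)c(OC)c2)c2c1C=CC(C)(C)O2` gives 9150 nM in this assay. Compound 2 `COc1ccc(C(=O)/C=C/c2ccc(-c3ccccc3)cc2)c2c1C=CC(C)(C)O2` reaches only the limit of this assay, > 10000 nM. Compound 3 `COc1ccc(/C=C/C(=O)c2ccc(OC)c3c2OC(C)(C)C=C3)cn1` likewise gives only a limit, > 10000 nM. So compound 3 stands at a boundary rather than at a number, and it shares that boundary with one other compound, since (the limit of > 10000 nM in this assay, at which 2 of the 3 values shown sit). Only compound 1 has a number at all, and that number sits close to the same boundary.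

The next compound, compound 4 `COc1ccc(C(=O)/C=C/c2ccc(O)cc2)c2c1C=CC(C)(C)O2`, differs from compound 3 in one place: 4-hydroxyphenyl in place of 6-methoxypyridin-3-yl on a double-bonded chain carbon bound to a double-bonded chain carbon. Among the measured compounds shown here, no measured pair in this set differs in exactly this way, so the size of the step can only be estimated. In this assay the expected step is an at least 1.2-fold lower number from compound 3 to compound 4 (0.09 log units; that floor lies within the scatter), a modest gain at most, and a result that stops at the limit again would not be surprising. Compound 4 is therefore expected to give about 8000 nM, somewhere between 2000 nM and 30000 nM.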

Compound 4, half-maximal inhibitory concentration: > 10000 nM
Compound 4 was reported as a limit; the forecaster's own chance of this, stated with the estimate: 45%; middle value at least 1.2-fold (0.09 log units) from the limit.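

Compound 4 stops at a limit, as compound 2 and compound 3 do, so neither step to compound 4 can be read: the limit of > 10000 nM in this assay, at which 3 of the 4 values shown sit.

The compounds shown leave open how far compound 2, compound 3 and compound 4 lie beyond that limit, and whether 4-hydroxyphenyl in place of 6-methoxypyridin-3-yl changes anything.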